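This account rests on a few compounds, and the source may have more. Where it says the series, first, only, none or still open, it means among the compounds named here.

Measured so far in an ADME assay on microsomes from liver (Mus musculus) for metabolic stability, read by LC-MS, tested at 1 uM; on this read-out higher numbers stand for fast clearance and lower numbers for slow clearance:
compound 1 `CCOC(=O)C1=C(C)N/C(=C/c2cc(C)n(-c3ccc(F)cc3F)c2C)C1=O`: 77 mL.min-1.g-1
compound 2 `CCOC(=O)C1=C(C)N/C(=C/c2cc(C)n(-c3ccc(OC)cc3)c2C)C1=O`: 54 mL.min-1.g-1
compound 3 `CCOC(=O)C1=C(C)N/C(=C/c2cc(C)n(-c3ccc(SC(F)(F)F)cc3)c2C)C1=O`: 76 mL.min-1.g-1

The three numbers sit close together: a 1.4-fold lower number from compound 1 to compound 2 (0.15 log units; within the scatter) and a 1.4-fold higher number from compound 2 to compound 3 (0.15 log units; within the scatter) are both within the scatter, so compound 2 stands level with compound 1 and compound 3 in this assay.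

Compound 4 `CCOC(=O)C1=C(C)N/C(=C/c2cc(C)n(-c3cccnc3)c2C)C1=O` is the next member; the change is pyridin-3-yl in place of 4-methoxyphenyl on an aromatic nitrogen. The two measured steps bear on it directly, since each also swaps the group on that aromatic nitrogen, and neither moved the number beyond the scatter. The expectation is therefore no step beyond the scatter in this assay, with a 1.0-fold higher number from compound 2 to compound 4 (0.01 log units; within the scatter) as the expected step. Compound 4 is estimated at 55 mL.min-1.g-1, range 30 mL.min-1.g-1 to 100 mL.min-1.g-1.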

Compound 4, intrinsic clearance in microsomes: 82 mL.min-1.g-1
Compound 4: middle estimate off by 1.5-fold (0.17 log units), on the low side, within the range that was stated.
By their numbers in this assay, from the lowest: compounds 2, 3, 1 and 4 (each within the scatter of the next).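

In this assay the group on the aromatic nitrogen now includes a ring with a hetero atom: pyridin-3-yl gives a 1.5-fold higher number from compound 2 to compound 4 (0.18 log units; within the scatter) and a 1.1-fold higher number from compound 1 to compound 4 (0.03 log units; within the scatter). All four groups at this place therefore stand level, whether the ring is of carbon only or holds a hetero atom. Nothing available explains this flat picture.

From the compounds shown here alone, whether a non-aromatic group on this nitrogen, such as a cyclohexyl or a longer alkyl chain, or a phenyl bearing an amine or a carboxylic acid, would stay level remains open. So does the effect of changes elsewhere on the shared core.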